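A few compounds are considered here, and "the series" means these few. Any claim that something is new, unique, unknown or untested is made for them only; others in the source may bear on it.

Measured compounds:
compound 1, `Cc1ccc(OCC(=O)N(Cc2cccs2)c2ncco2)cc1`, 0.3 nM
compound 2, `Cc1ccc(OCC(=O)N(Cc2cccs2)c2ccccn2)cc1`, 200 nM
compound 3, `Cc1ccc(OCC(=O)N(Cc2cccs2)c2ccncc2)cc1`, 52 nM

In an assay on HEK293 cells for agonist activity at transient receptor potential cation channel subfamily M member 8 (Homo sapiens), read by fluorescence and calcium flux, with a stated time of 15 min (on this read-out higher numbers stand for an effect only at larger amounts of compound and lower numbers for an effect already at smaller amounts), compound 3 stands second highest of the three numbers: the nearest is compound 2, with a 3.8-fold lower number from compound 2 to compound 3 (0.59 log units; beyond the scatter), and the furthest is compound 1, with a 170-fold higher number from compound 1 to compound 3 (2.24 log units; beyond the scatter). Compound 4, `Cc1ccc(OCC(=O)N(CCO)Cc2cccs2)cc1`, has not yet been measured in this assay. It differs from compound 3 in one place: 2-hydroxyethyl in place of pyridin-4-yl on an amide-type nitrogen.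

Among the compounds with values here, none of the measured steps makes this exact change; all three exchange one aromatic ring for another on the same nitrogen. They show that the group on that nitrogen matters a great deal, as a 670-fold higher number from compound 1 to compound 2 (2.82 log units; beyond the scatter) and a 170-fold higher number from compound 1 to compound 3 (2.24 log units; beyond the scatter) are large, while a 3.8-fold lower number from compound 2 to compound 3 (0.59 log units; beyond the scatter) is modest. Here the ring is removed altogether and a short 2-hydroxyethyl chain enters, a change outside what these steps cover. Given how strongly this assay answers to that position, a step beyond the scatter is expected, most likely toward a higher number, with wide uncertainty in either direction. The step of a 9.6-fold higher number from compound 3 to compound 4 (0.98 log units; beyond the scatter) is the expected outcome. Compound 4 is therefore estimated at 500 nM, within a range from 50 nM to 5000 nM.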

Compound 4, half-maximal effective concentration: 900 nM
Compound 4: middle estimate off by 1.8-fold (0.26 log units), on the low side, within the range that was stated.
By their numbers in this assay, from the lowest: compound 1; then compound 3; then compound 2; then compound 4.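

Until this point only aromatic rings had stood on the amide-type nitrogen, and with the open 2-hydroxyethyl chain there, compound 4 gives the highest number of the four in this assay, with a 17-fold higher number from compound 3 to compound 4 (1.24 log units; beyond the scatter) and a 4.5-fold higher number from compound 2 to compound 4 (0.65 log units; beyond the scatter). The size of the step depends heavily on which ring leaves: the pyridine compounds lie much closer to the chain than the 1,3-oxazol-2-yl compound does, with a 3000-fold higher number from compound 1 to compound 4 (3.48 log units; beyond the scatter), and among these four compounds each ring gives a lower number than the chain, with none going against this. No measurement at hand explains this order.

The compounds shown leave open whether the step follows from the loss of the ring or from the hydroxyl at the end of the chain, a question that a plain ethyl group or a 2-aminoethyl chain on the same nitrogen could help to separate. They also leave open how the number responds to a longer chain, or to a carboxylic acid at the end of the chain.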